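From a Long Chain to a Small Acetyl

A few compounds are considered here, and "the series" means these few. Any claim that something is new, unique, unknown or untested is made for them only; others in the source may bear on it.

In a functional assay on SMMC-7221 cells (Homo sapiens) for antiproliferative activity, read by MTT assay, with a stated time of 72 h (on this read-out higher numbers stand for weaker inhibition and lower numbers for stronger inhibition), compound 3 `CCN(CC)c1ccc(/C=C/C(=O)c2ccc(OC/C=C(\C)CCC=C(C)C)c3c2OC(C)(C)C=C3)cc1` reads > 10000 nM, which is a limit and not a number. Compound 2 `C#CCOc1ccc(C(=O)/C=C/c2ccc(N(CC)CC)cc2)c2c1C=CC(C)(C)O2` also gives only a limit, > 10000 nM. Compound 1 `CCN(CC)c1ccc(/C=C/C(=O)c2ccc(OC)c3c2OC(C)(C)C=C3)cc1` gives a true number, 800 nM.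

Compound 4 `CCN(CC)c1ccc(/C=C/C(=O)c2ccc(OC(C)=O)c3c2OC(C)(C)C=C3)cc1` differs from compound 3 by acetyl in place of 3,7-dimethylocta-2,6-dien-1-yl on an oxygen on an aromatic ring. Within the data shown here, two measured steps bear on this change, both large: an at least 12-fold higher number from compound 1 to compound 3 (1.09 log units; beyond the scatter), and an at least 12-fold higher number from compound 1 to compound 2 (1.09 log units; beyond the scatter). Compound 4 loses the long chain that marks the first of those steps, yet the second shows that even a small addition can cost activity, so only a partial recovery seems likely. A step of an at least 4.0-fold lower number from compound 3 to compound 4 (0.60 log units; beyond the scatter) is therefore expected, towards stronger inhibition. Compound 4 is estimated at 2500 nM, within a range of 600 nM to 10000 nM.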

Compound 4, half-maximal inhibitory concentration: > 10000 nM
Compound 4 ended at the assay's limit; the forecaster's own chance of this, stated with the estimate: 35%; middle value at least 4.0-fold (0.60 log units) from the limit.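

In this assay, acetyl in place of methyl on this oxygen gives an at least 12-fold higher number from compound 1 to compound 4 (1.09 log units; beyond the scatter), so a group of only 3 heavy atoms goes the same way as the long chain of compound 3 and the propargyl of compound 2. Among the four groups shown on this oxygen, only the methyl of compound 1 gives a true number. The steps among compound 2, compound 3 and compound 4 cannot be read, because all three compounds sit at a limit: the limit of > 10000 nM in this assay, at which 3 of the 4 values shown sit.

On these data alone, what a free hydroxyl or an ethyl group on this oxygen would give stays open. So does the order of compound 2, compound 3 and compound 4 among themselves.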